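From Propylamino to Isopropylamino on a Shared Core

This account rests on a few compounds, and the source may have more. Where it says the series, first, only, none or still open, it means among the compounds named here.

Values in a functional assay for inhibition, with Homo sapiens as the target; on this read-out higher numbers stand for an effect only at larger amounts of compound and lower numbers for an effect already at smaller amounts:
Compound 1, `CC(Cl)C(=O)Nc1ccc(C2=NNC(=O)CC2)cc1`: 0.45 ug/mL
Compound 2, `CCCNCC(=O)Nc1ccc(C2=NNC(=O)CC2)cc1`: about 46.4 ug/mL
Compound 3, `CC(C)NCC(=O)Nc1ccc(C2=NNC(=O)CC2)cc1`: not yet measured

Within the data shown here, compound 2 holds the higher of the two numbers in this assay, at about 46.4 ug/mL, and compound 1 is its only neighbour on this scale. Compound 3 has the same atoms as compound 2, joined differently: isopropyl in place of propyl on an amine nitrogen, with isopropyl in place of propyl on an amine nitrogen.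

Among the measured compounds shown here, only one measured step bears on this change, and it does so indirectly. That step, a 100-fold higher number from compound 1 to compound 2 (2.01 log units; beyond the scatter), is large and beyond the scatter, but it put (propylamino)methyl in place of 1-chloroethyl on a carbonyl carbon, which is a far larger replacement than the one at hand. For the measured compounds named here, no measured pair isolates propyl against isopropyl, so the direction remains open, and no step beyond the scatter is expected. The estimated change is a 1.2-fold lower number from compound 2 to compound 3 (0.06 log units; within the scatter). Compound 3 is expected at 40 ug/mL, with an estimated range from 12 ug/mL to 110 ug/mL.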

Compound 3, half-maximal effective concentration: about 46.4 ug/mL
Compound 3: the middle estimate sits 1.2-fold (0.06 log units) below what was measured; measured number inside the range.
By their numbers in this assay, from the lowest: compound 1; then compounds 2 and 3 (each within the scatter of the next).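

In this assay, among these compounds, the first pair to isolate this change on the amine nitrogen gives no change at the digits printed from compound 2 to compound 3 (within the scatter), so exchanging propyl for isopropyl, two groups with the same count of carbons, leaves no step that can be read beyond the scatter. The large gap to the chloro compound also remains with the branched chain, which gives a 100-fold higher number from compound 1 to compound 3 (2.01 log units; beyond the scatter), and at the digits printed this matches the step already seen for the propylamino compound. Nothing measured here offers an explanation for why the number holds across this exchange.

As far as these compounds go, it remains open whether the same holds for groups further removed from these two, such as a longer chain like butyl, a cyclopropyl ring or a second alkyl group on the amine nitrogen. Also open, from the compounds shown here alone, is which part of the replacement of 1-chloroethyl carries the large step, as the amine and the chlorine are exchanged together in both compound 2 and compound 3, and a simple chloromethyl group or a primary amine on the same carbonyl carbon would separate these two parts.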